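Amino for hydrogen on the core of compound 2: expectation

A few compounds are considered here, and "the series" means these few. Any claim that something is new, unique, unknown or untested is made for them only; others in the source may bear on it.

Compound 1, `O=c1[nH]cnc2c1c(-c1ccsc1)cn2[C@@H]1O[C@H](CO)[C@@H](O)[C@H]1O`: in a functional assay on HCT-116 cells (Homo sapiens), read by MTT assay, with a stated time of 72 h (on this read-out lower numbers stand for stronger inhibition and higher numbers for weaker inhibition), compound 1 gives > 20000 nM, a limit of the assay.
Compound 2, `O=c1[nH]cnc2c1c(-c1cccs1)cn2[C@@H]1O[C@H](CO)[C@@H](O)[C@H]1O`: in this assay compound 2 gives > 20000 nM, also a limit.
Compound 3, `O=c1[nH]cnc2c1c(-c1ccccc1)cn2[C@@H]1O[C@H](CO)[C@@H](O)[C@H]1O`: in this assay compound 3 gives > 20000 nM, again a limit.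

Compound 2 stands at the same limit as the other two measured compounds, so the numbers place it nowhere in particular among them. All three share one core and differ only in the aryl group on an aromatic carbon. The steps among them, a step that the two limits leave unreadable from compound 1 to compound 2, a step that the two limits leave unreadable from compound 1 to compound 3 and a step that the two limits leave unreadable from compound 2 to compound 3, cannot be read, because of the limit of > 20000 nM in this assay, at which 3 of the 3 values shown sit.

Compound 4, `Nc1nc2c(c(-c3cccs3)cn2[C@@H]2O[C@H](CO)[C@@H](O)[C@H]2O)c(=O)[nH]1`, differs from compound 2 by amino in place of hydrogen on an aromatic carbon. For the measured compounds named here, no measured step bears on this change: the three that exist all run between two limits and give no size and no direction. Going by the values given here, what is known is only that every measured compound sits at the limit in this assay. Compound 4 is therefore expected to give 25000 nM, within 8000 nM to 80000 nM, most likely reported again as a limit. The expected step from compound 2 is a step that the limit leaves unreadable from compound 2 to compound 4, which cannot be distinguished from no change.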

Compound 4, half-maximal inhibitory concentration: 19800 nM
Estimate against measurement, compound 4: 1.3-fold (0.10 log units) above; measured number inside the range.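

In this assay compound 4 gives 19800 nM as a measured number. Compound 4 is the only one of the four compounds shown that does not sit at a limit, so amino on this aromatic carbon between two ring nitrogen atoms is the one change here that yields a value that can be read. For compound 2 the assay gives only a limit, > 20000 nM, which is not a number. Amino in place of hydrogen therefore gives a number no higher from compound 2 to compound 4 (the limit leaves the size open), and the earlier compounds could not show even this much, because the size of the step remains hidden behind the ceiling of the assay: the limit of > 20000 nM in this assay, at which 3 of the 4 values shown sit.

On these data alone, the steps among compound 1, compound 2 and compound 3 still cannot be read, so it stays open whether the aryl group matters at all, and whether amino would give a measurable number with phenyl or thiophen-3-yl in place of thiophen-2-yl. As far as these compounds go, it is also open how a methylamino or a methyl group on the same carbon would compare with amino.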